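A few compounds are considered here, and "the series" means these few. Any claim that something is new, unique, unknown or untested is made for them only; others in the source may bear on it.

Compound 3 `COc1cc(OCc2csc(-c3ccc(C(N)=O)cc3)n2)c2cc(-c3cn4nc(OC)sc4n3)oc2c1` gives 0.3 nM in a functional assay on HEK293 cells for antagonist activity at proteinase-activated receptor 4 (Homo sapiens), read by FLIPR and calcium flux, with a stated time of 30 min (on this read-out higher numbers stand for weaker inhibition and lower numbers for stronger inhibition), the lowest of the three numbers measured; compound 1 `COc1cc(OCc2csc(-c3ccc(C(F)(F)F)cc3)n2)c2cc(-c3cn4nc(OC)sc4n3)oc2c1` gives 1.3 nM and compound 2 `COc1cc(OCc2csc(-c3ccc(C(C)(C)O)cc3)n2)c2cc(-c3cn4nc(OC)sc4n3)oc2c1` gives 2.4 nM. Compound 4 `COc1cc(OCc2csc(N3CCOCC3=O)n2)c2cc(-c3cn4nc(OC)sc4n3)oc2c1` has not yet been measured; it differs from compound 3 by 3-oxomorpholin-4-yl in place of 4-carbamoylphenyl on an aromatic carbon. The steps measured so far change only the substituent carried by the ring that leaves: a 4.3-fold lower number from compound 1 to compound 3 (0.64 log units; beyond the scatter) and an 8.0-fold lower number from compound 2 to compound 3 (0.90 log units; beyond the scatter), both modest. Neither step removes the ring itself, so they bear on this new step only loosely, and the expectation is a weaker result than compound 3, beyond the scatter. Compound 4 is expected to give 3 nM, within a range from 0.5 nM to 20 nM, an estimated step of a 10-fold higher number from compound 3 to compound 4 (1.00 log units; beyond the scatter).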

Compound 4, half-maximal inhibitory concentration: 1.7 nM
Beside the measured number, compound 4's estimate is 1.8-fold (0.25 log units) above it; low and high end bracket the measured number.
By their numbers in this assay, from the lowest: compound 3; then compounds 1, 4 and 2 (each within the scatter of the next).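

In this assay, the phenyl ring at this position can be replaced by a non-aromatic ring: 3-oxomorpholin-4-yl, with no hydrogen-bond donor, matches the 4-(1-hydroxy-1-methylethyl)phenyl and 4-(trifluoromethyl)phenyl groups (a 1.4-fold lower number from compound 2 to compound 4 (0.15 log units; within the scatter); a 1.3-fold higher number from compound 1 to compound 4 (0.12 log units; within the scatter)). The 4-carbamoylphenyl group of compound 3 goes against this, since replacing it costs activity (a 5.7-fold higher number from compound 3 to compound 4 (0.75 log units; beyond the scatter)). No evidence at hand explains these results.

The compounds shown leave open whether plain morpholin-4-yl, lacking the ring carbonyl, would match 3-oxomorpholin-4-yl. They also leave open how an amine or a carboxylic acid on the phenyl ring would compare with carbamoyl.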